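From thiophen-3-yl to 4-chlorophenyl on the shared core

The compounds below may be only part of what the source reports. "The series", "measured", "known", "first", "only" and "open" are said of these compounds alone.

Measured in a physicochemical assay for solubility, at pH 7; on this read-out lower numbers stand for lower solubility and higher numbers for higher solubility:
Compound 1 `CN1CCC(C(=O)N2Cc3c(NC(=O)C4CC4)n[nH]c3C2(C)C)CC1`: > 225000 nM, a limit
Compound 2 `CN1CCC(C(=O)N2Cc3c(NC(=O)c4ccsc4)n[nH]c3C2(C)C)CC1`: > 225000 nM, a limit

Compound 2 has no number of its own, only the limit > 225000 nM. Compound 3 `CN1CCC(C(=O)N2Cc3c(NC(=O)c4ccc(Cl)cc4)n[nH]c3C2(C)C)CC1` differs from it by one change, (4-chlorophenyl in place of thiophen-3-yl on a carbonyl carbon), with 4-chlorophenyl in place of thiophen-3-yl on a carbonyl carbon. Among the measured compounds shown here, one measured step bears on this, a step that the two limits leave unreadable from compound 1 to compound 2, as it also exchanged the group on a carbonyl carbon. Its size cannot be read, and both measured compounds stand at the limit of > 225000 nM in this assay, at which 2 of the 2 values shown sit. The data therefore offer no measured size for the new step, and any direction remains a cautious expectation. A moderate fall in this assay is expected, estimated as an at least 1.8-fold lower number from compound 2 to compound 3 (0.27 log units; that floor lies within the scatter). For compound 3 the estimated value is 120000 nM, with an expected range from 30000 nM to 225000 nM.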

Compound 3, solubility: > 225000 nM
Compound 3: a limit, no number (the forecaster's own chance of this, stated with the estimate: 40%); middle value at least 1.8-fold (0.27 log units) away from the limit.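

Among the compounds shown here, neither the step from compound 2 to compound 3 nor the one from compound 1 to compound 3 can be read, since each compares two limits: the limit of > 225000 nM in this assay, at which 3 of the 3 values shown sit.

The compounds shown leave open whether cyclopropyl, thiophen-3-yl and 4-chlorophenyl on the carbonyl carbon differ at all in this assay or by how much.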